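The compounds below may be only part of what the source reports. "The series", "measured", "known", "first", "only" and "open" are said of these compounds alone.

Going by the values given here, in a functional assay on HEK293 cells for antagonist activity at thromboxane A2 receptor (Homo sapiens), read by fluorescence and calcium flux (on this read-out higher numbers stand for weaker inhibition and lower numbers for stronger inhibition), compound 1 `Cc1ccccc1Oc1ccc(C#N)cc1S(=O)(=O)NC(=O)NC(C)(C)C` gives 3690 nM, and compound 2 `Cc1cccc(Oc2ccc(C#N)cc2S(=O)(=O)NC(=O)NC(C)(C)C)c1` gives 1050 nM, the one measured step being a 3.5-fold lower number from compound 1 to compound 2 (0.55 log units; beyond the scatter). Compound 2 therefore holds the lowest of the two numbers. Compound 3 `Cc1ccc(Oc2ccc(C#N)cc2S(=O)(=O)NC(=O)NC(C)(C)C)cc1` differs from compound 2 by 4-methylphenyl in place of 3-methylphenyl on an oxygen on an aromatic ring. Among the compounds with values here, only that single measured step bears on this change: it moved the same methyl once, and one step does not fix the direction of a further move. The expected outcome is a 1.1-fold lower number from compound 2 to compound 3 (0.02 log units; within the scatter), nothing beyond the scatter. Compound 3 is accordingly estimated at 1000 nM, in the range 300 nM to 3500 nM.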

Compound 3, half-maximal inhibitory concentration: 750 nM
Compound 3: middle estimate off by 1.3-fold (0.12 log units), on the high side; the measured number falls inside the stated range.
By their numbers in this assay, from the lowest: compounds 3 and 2 (each within the scatter of the next); then compound 1.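

In this assay the move from 3-methylphenyl to 4-methylphenyl gives a 1.4-fold lower number from compound 2 to compound 3 (0.15 log units; within the scatter), so this read-out does not separate these two methyl placements on the ring carried by the oxygen. The comparison with 2-methylphenyl gives a 4.9-fold lower number from compound 1 to compound 3 (0.69 log units; beyond the scatter), leaving compound 1 apart from both compound 2 and compound 3. No measurement available here explains this difference.

Open, from the compounds shown here alone, is how the unsubstituted phenyl compares, and whether chloro, methoxy or trifluoromethyl in place of methyl would show the same dependence on placement.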